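Removing One Side Chain from a Weakly Cytotoxic Dimer

This account rests on a few compounds, and the source may have more. Where it says the series, first, only, none or still open, it means among the compounds named here.

Among the measured compounds shown here, compound 2 `C=C1C(=O)O[C@H]2[C@H]1[C@@H](OC(=O)/C(C)=C/C)C[C@@](C)(O)[C@]13C=C[C@](C)([C@H]21)[C@]1(C3)C(=O)O[C@@H]2[C@H]3C(C)=CC[C@H]3[C@](C)(O)C[C@H](OC(=O)/C(C)=C/C)[C@H]21` is the only compound that returns a number in a functional assay on HT-29 cells (Homo sapiens) for cytotoxicity, read by MTT assay, with a stated time of 48 h (on this read-out lower numbers stand for stronger inhibition and higher numbers for weaker inhibition), where compound 2 gives 9600 nM. Compound 1 `C=C1C(=O)O[C@@H]2[C@@H]3[C@@]4(C=C[C@@]3(C)[C@]3(C4)C(=O)O[C@@H]4[C@H]5C(C)=CC[C@H]5[C@](C)(O)C[C@H](O)[C@H]43)[C@](C)(O)CC[C@@H]12` reaches only a limit of the assay in this assay, at > 10000 nM (the limit of > 10000 nM in this assay, at which 1 of the 2 values shown sits). Compound 3 `C=C1C(=O)O[C@@H]2[C@@H]3[C@@]4(C=C[C@@]3(C)[C@]3(C4)C(=O)O[C@@H]4[C@H]5C(C)=CC[C@H]5[C@](C)(O)C[C@H](OC(=O)/C(C)=C/C)[C@H]43)[C@](C)(O)CC[C@@H]12` differs from compound 2 by hydrogen in place of ((1-methylprop-1-en-1-yl)carbonyl)oxy on a saturated ring carbon. For the measured compounds named here, no measured step between compounds differing in one place is available, so the size of this change cannot be anchored. Compound 3 is expected to sit near compound 2, with a step of a 1.3-fold higher number from compound 2 to compound 3 (0.10 log units; within the scatter) that need not exceed the scatter and may reach the limit. Compound 3 is estimated at 12000 nM, between 5000 nM and 30000 nM.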

Compound 3, half-maximal inhibitory concentration: > 10000 nM
Compound 3 ended at the assay's limit; the forecaster's own chance of this, stated with the estimate: 55%; the middle value does not contradict the limit.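

In this assay, replacing the ((1-methylprop-1-en-1-yl)carbonyl)oxy group on this saturated ring carbon with hydrogen gives an at least 1.0-fold higher number from compound 2 to compound 3 (0.01 log units; that floor lies within the scatter); this is only a floor, so the true size of the step may be larger. The step that links compound 1 and compound 3 cannot be read. Compound 2 alone keeps a number, and the rest of the set stands at a limit: the limit of > 10000 nM in this assay, at which 2 of the 3 values shown sit.

As far as these compounds go, how far the removal really weakens the compound stays open. So does whether an amine or a longer chain on this ring carbon would return a number in this assay.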